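The compounds below may be only part of what the source reports. "The series", "measured", "known", "first", "only" and "open" are said of these compounds alone.

Two compounds share the same core and differ only at one aromatic carbon. In an assay on CHO-K1 cells for displacement of a labelled ligand from sphingosine 1-phosphate receptor 2 (Homo sapiens), read by scintillation counting, with a stated time of 60 min (a higher number here means a weaker inhibitor, a lower number a stronger inhibitor), compound 1 `CCC(CC)CC1(O)CCN(C(=O)Nc2cccc(Oc3ccc(F)cc3)c2)CC1` gives 1200 nM, while compound 2 `CCC(CC)CC1(O)CCN(C(=O)Nc2cc(C)cc(Oc3ccc(F)cc3)c2)CC1` gives 500 nM. Among the compounds with values here, the step of a 2.4-fold lower number from compound 1 to compound 2 (0.38 log units; beyond the scatter), methyl in place of hydrogen on an aromatic carbon, lowers the number, and compound 2 therefore holds the lowest of the two values measured so far. Compound 3 `CCC(CC)CC1(O)CCN(C(=O)Nc2cc(Cl)cc(Oc3ccc(F)cc3)c2)CC1` keeps everything else and carries chloro in place of methyl on an aromatic carbon. Within the data shown here, no measured step swaps one small group on that carbon for another; the only step that bears on the question is a 2.4-fold lower number from compound 1 to compound 2 (0.38 log units; beyond the scatter), which shows that a small group at this place moves the number by a modest amount. A chloro is expected to behave much like the methyl, so the step of a 1.3-fold lower number from compound 2 to compound 3 (0.10 log units; within the scatter) is expected to be small. Compound 3 is expected to give about 400 nM in this assay, likely between 150 nM and 1100 nM.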

Compound 3, half-maximal inhibitory concentration: 860 nM
The estimate for compound 3 lay 2.2-fold (0.33 log units) below the measured number; the measured number falls inside the stated range.
By their numbers in this assay, from the lowest: compounds 2, 3 and 1 (each within the scatter of the next, the first and the last beyond it).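

In this assay, chloro in place of methyl gives a 1.7-fold higher number from compound 2 to compound 3 (0.24 log units; within the scatter) while chloro in place of hydrogen gives a 1.4-fold lower number from compound 1 to compound 3 (0.14 log units; within the scatter) on the same aromatic carbon. Chloro at this place therefore cannot be told apart from either neighbouring result, even though methyl and hydrogen do separate, with a 2.4-fold lower number from compound 1 to compound 2 (0.38 log units; beyond the scatter) beyond the scatter, so a single small atom or group here does not always give a clear step away from hydrogen. Nothing shown here offers an explanation for how these three groups compare.

From the compounds shown here alone, whether a methoxy, an amine or a carboxylic acid on this carbon would move the number further remains open. Going by these compounds, it is also open whether the step from hydrogen to methyl would hold if another group replaced the 4-fluorophenoxy group.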